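Trifluoromethyl for Methyl: Expected Effect on Antiproliferative Potency

A few compounds are considered here, and "the series" means these few. Any claim that something is new, unique, unknown or untested is made for them only; others in the source may bear on it.

Measured compounds:
compound 1, `Nc1nc(N)c2cc(CSC(=S)N3CCN(C4CCCCC4)CC3)ccc2n1`: 6800 nM
compound 2, `Cc1ccc(N2CCN(C(=S)SCc3ccc4nc(N)nc(N)c4c3)CC2)cc1`: 2480 nM
compound 3, `Cc1ccc(N2CCN(C(=S)SCc3ccc4nc(N)nc(N)c4c3)CC2)c(C)c1`: 3120 nM

In a functional assay on MCF7 cells (Homo sapiens) for antiproliferative activity, read by MTT assay, with a stated time of 72 h (on this read-out lower numbers stand for stronger inhibition and higher numbers for weaker inhibition), compound 2 gives the lowest of the three numbers. The step of a 1.3-fold higher number from compound 2 to compound 3 (0.10 log units; within the scatter) lies within the scatter, so compound 2 and compound 3 cannot be ordered, whereas the step of a 2.7-fold lower number from compound 1 to compound 2 (0.44 log units; beyond the scatter) is beyond it, as is a 2.2-fold lower number from compound 1 to compound 3 (0.34 log units; beyond the scatter).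

Compound 4, `Nc1nc(N)c2cc(CSC(=S)N3CCN(c4ccc(C(F)(F)F)cc4)CC3)ccc2n1`, differs from compound 2 by trifluoromethyl in place of methyl on an aromatic carbon. Among the compounds with values here, no measured step exchanges one substituent on that aromatic ring for another of a different kind; the nearest comparison is a 1.3-fold higher number from compound 2 to compound 3 (0.10 log units; within the scatter), which adds a methyl on an aromatic carbon and stays within the scatter. The larger steps from compound 1 concern the exchange of cyclohexyl for an aryl group and do not speak to this change. Compound 4 is therefore expected to show no step beyond the scatter in this assay, and the expected step is a 1.0-fold higher number from compound 2 to compound 4 (0.00 log units; within the scatter). Compound 4 is estimated at 2500 nM, with a range from 1000 nM to 6500 nM.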

Compound 4, half-maximal inhibitory concentration: 7400 nM
Compound 4: middle estimate off by 3.0-fold (0.47 log units), on the low side, and the stated range ends below it.
By their numbers in this assay, from the lowest: compounds 2 and 3 (each within the scatter of the next); then compounds 1 and 4 (each within the scatter of the next).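

In this assay, within the data shown here, the substituent at this place on the aromatic ring proves to matter, with a 3.0-fold higher number from compound 2 to compound 4 (0.47 log units; beyond the scatter) as the first step beyond the scatter that exchanges one substituent there for another, whereas the added methyl of compound 3 had stayed within it. An aryl group in place of cyclohexyl on the amine nitrogen therefore does not lower the number by itself: compounds 2 and 3 follow that pattern, but compound 4 goes against it, with a 2.4-fold higher number from compound 3 to compound 4 (0.38 log units; beyond the scatter) on one side and a 1.1-fold higher number from compound 1 to compound 4 (0.04 log units; within the scatter) on the other. Nothing available accounts for this difference.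

The compounds shown leave open whether a chlorine atom, a methoxy or a nitrile at this place would give a number close to that of compound 2 or of compound 4. They also leave open whether hydrogen there would differ from methyl.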